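A Methoxy-to-Nitro Swap With One Number Still Open

The source may hold more compounds than are shown below. What is called first, only, known or untested is meant among the compounds shown, and "the series" means these compounds.

Within the data shown here, in a functional assay on Jurkat cells (Homo sapiens) for cytotoxicity, read by MTT assay, with a stated time of 48 h (on this read-out lower numbers stand for stronger inhibition and higher numbers for weaker inhibition), compound 1 (`O=C(/C=C/c1ccc(NC(=O)Nc2ccccc2)cc1)NO`) gives 1200 nM and compound 2 (`COc1ccc(NC(=O)Nc2ccc(/C=C/C(=O)NO)cc2)cc1`) gives 700 nM as the only other number so far, and the two lie within the scatter of each other. Compound 3 (`O=C(/C=C/c1ccc(NC(=O)Nc2ccc([N+](=O)[O-])cc2)cc1)NO`) has nitro in place of methoxy on an aromatic carbon and is not yet measured. Among the measured compounds shown here, the one measured step at that carbon (a 1.7-fold lower number from compound 1 to compound 2 (0.23 log units; within the scatter)) put methoxy in place of hydrogen and stayed within the scatter. For the measured compounds named here, no nitro compound has a number yet, so no step beyond the scatter is expected in this assay for this change. The expected step is small (a 1.4-fold higher number from compound 2 to compound 3 (0.15 log units; within the scatter)). For compound 3 the expected value is 1000 nM (350 nM to 3000 nM).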

Compound 3, half-maximal inhibitory concentration: 700 nM
The estimate for compound 3 lay 1.4-fold (0.15 log units) above the measured number; low and high end bracket the measured number.
By their numbers in this assay, from the lowest: compounds 2, 3 and 1 (each within the scatter of the next).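

In this assay, nitro in place of methoxy gives no change at the digits printed from compound 2 to compound 3 (within the scatter) and nitro in place of hydrogen gives a 1.7-fold lower number from compound 1 to compound 3 (0.23 log units; within the scatter) at this aromatic carbon. So a second group, built from different atoms than methoxy, also stays within the scatter of compound 1, which carries hydrogen there. No supporting measurement bears on the reason for this. Among these compounds, still open is whether an amine or a carboxylic acid on this same carbon would also stay within the scatter, or would instead produce the first step beyond it.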